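Chloro in place of cyclopropyl: expected step

This account rests on a few compounds, and the source may have more. Where it says the series, first, only, none or still open, it means among the compounds named here.

Of the compounds shown here, three sharing one core have been measured in a toxicity assay on mitochondria from liver (Rattus norvegicus) for inhibition, in the presence of a further agent that is not named here; a lower number here means a stronger inhibitor, a higher number a weaker inhibitor. Compound 1 `N#Cc1cc(C(=O)N2CCc3ccccc32)cc(I)c1O`, carrying iodo, gives 53000 nM. Compound 2 `CSc1cc(C(=O)N2CCc3ccccc32)cc(C#N)c1O`, carrying methylsulfanyl, gives 40000 nM. Compound 3 `N#Cc1cc(C(=O)N2CCc3ccccc32)cc(C2CC2)c1O`, carrying cyclopropyl, gives 24000 nM. Compound 3 is separated from only one of the other two: a 2.2-fold lower number from compound 1 to compound 3 (0.34 log units; beyond the scatter), whereas a 1.7-fold lower number from compound 2 to compound 3 (0.22 log units; within the scatter).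

Compound 4 `N#Cc1cc(C(=O)N2CCc3ccccc32)cc(Cl)c1O` has chloro in place of cyclopropyl on an aromatic carbon, ortho to a hydroxy group and meta to a cyano group (chloro in place of cyclopropyl on an aromatic carbon). Among the measured compounds shown here, no chloro compound has been measured in this set. The nearest guide is compound 1, the other halogen member, with a 2.2-fold lower number from compound 1 to compound 3 (0.34 log units; beyond the scatter); read in reverse, this points towards a higher number on leaving cyclopropyl. The exchange of iodo for methylsulfanyl, a 1.3-fold lower number from compound 1 to compound 2 (0.12 log units; within the scatter), shows that not every change here exceeds the scatter. The expected step in this assay is therefore modest and upward, a 1.7-fold higher number from compound 3 to compound 4 (0.22 log units; within the scatter). For compound 4 the estimated value is 40000 nM, with an expected range of 20000 nM to 75000 nM.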

Compound 4, half-maximal inhibitory concentration: 31000 nM
Estimate against measurement, compound 4: 1.3-fold (0.11 log units) above; the range from low to high includes it.
By their numbers in this assay, from the lowest: compounds 3, 4, 2 and 1 (each within the scatter of the next, the first and the last beyond it).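

In this assay the steps of a 1.3-fold higher number from compound 3 to compound 4 (0.11 log units; within the scatter) and a 1.3-fold lower number from compound 2 to compound 4 (0.11 log units; within the scatter) and a 1.7-fold lower number from compound 1 to compound 4 (0.23 log units; within the scatter) all show chloro, ortho to a hydroxy group and meta to a cyano group, as not separable from any of the three other groups at this position. Among the compounds shown here, the exchange of cyclopropyl, with its three-membered ring, for a single chlorine atom therefore gives no reading beyond the scatter, and among the four compounds only the pair of compound 1 and compound 3 remains separated. Nothing available bears on what lies behind these numbers.

As far as these compounds go, whether an amine, a carboxylic acid or a longer chain at this position would stay within this range remains open. Also open, from the compounds shown here alone, is whether chloro would give the same result on a core carrying something other than the cyano group.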